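Methoxy to hydroxy at the benzoyl end of compound 2

This account rests on a few compounds, and the source may have more. Where it says the series, first, only, none or still open, it means among the compounds named here.

Compound 2 `COc1ccc(C(=O)NNC(=S)Nc2csc(-c3ccc(C)cc3)c2)cc1` holds the lower of the two numbers seen so far: in a functional assay on MCF7 cells (Homo sapiens) for inhibition, read by colorimetric assay and MTT assay, with a stated time of 72 h (on this read-out higher numbers stand for weaker inhibition and lower numbers for stronger inhibition), compound 2 gives 5000 nM. Within the data shown here, compound 1 `COc1ccc(C(=O)NNC(=S)Nc2csc(-c3ccccc3)c2)cc1`, the only neighbour measured, gives 32000 nM in this assay, and the step of a 6.4-fold lower number from compound 1 to compound 2 (0.81 log units; beyond the scatter) is the single comparison of the series to date, with methyl in place of hydrogen on an aromatic carbon.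

Compound 3 `Cc1ccc(-c2cc(NC(=S)NNC(=O)c3ccc(O)cc3)cs2)cc1` differs from compound 2 by hydrogen in place of methyl on an oxygen on an aromatic ring, read one bond out as methoxy to hydroxy. Among the measured compounds shown here, no measured step touches this position; the one step available concerns a methyl on an aromatic carbon at the other end of the molecule, so it cannot be carried over. With nothing in the numbers pointing either way, compound 3 is expected to show a change of no change at the digits printed from compound 2 to compound 3 (within the scatter) in this assay, i.e. none beyond the scatter. Compound 3 is therefore estimated at 5000 nM in this assay, with a range of 1500 nM to 16000 nM.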

Compound 3, half-maximal inhibitory concentration: 42000 nM
Compound 3: the middle estimate sits 8.4-fold (0.92 log units) below what was measured, and the stated range ends below it.
By their numbers in this assay, from the lowest: compound 2; then compounds 1 and 3 (each within the scatter of the next).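

In this assay the methoxy at the benzoyl end turns out to be a place where the number responds: an 8.4-fold higher number from compound 2 to compound 3 (0.92 log units; beyond the scatter) is read for methoxy to hydroxy, whereas the earlier compounds had only shown a step for a methyl on an aromatic carbon at the other end of the molecule. The direction is towards weaker inhibition, so within this pair 4-methoxyphenyl is favoured over 4-hydroxyphenyl, and the series now has one step at each end of the molecule, each beyond the scatter and pointing in its own direction. Nothing at hand explains why this oxygen substituent matters.

The compounds shown leave open whether the step comes from gaining the hydroxy or from losing the methyl on that oxygen, a question that an ethoxy or a longer chain on the oxygen, or an amine or a fluorine in its place, could help to settle. They also leave open whether the same change gives a step of similar size on the core of compound 1, which lacks the methyl on the aromatic carbon.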